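Swapping a phenyl for a furan ring in cytotoxicity

The source may hold more compounds than are shown below. What is called first, only, known or untested is meant among the compounds shown, and "the series" means these compounds.

Compound 1, with structure `Clc1cccc(Cl)c1Cc1nnc(Nc2ccc(COCc3ccsc3)cc2)o1`, and compound 2, with structure `Clc1cccc(Cl)c1Cc1nnc(Nc2ccc(COCc3ccccc3)cc2)o1`, differ only in the ring at the end of the side chain. In an ADME assay on MT2 cells (Homo sapiens) for cytotoxicity, read by MTT assay (on this read-out higher numbers stand for lower toxicity in this test and lower numbers for higher toxicity in this test), compound 1 gives a value of > 100000 nM, which is a limit of the test rather than a number. In this assay, within the data shown here, compound 2 gives 84000 nM, the only plain number among the two values shown. The step of an at least 1.1-fold lower number from compound 1 to compound 2 (0.07 log units; that floor lies within the scatter) therefore tells little beyond its floor.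

Compound 3, with structure `Clc1cccc(Cl)c1Cc1nnc(Nc2ccc(COCc3ccco3)cc2)o1`, carries the change (furan-2-yl in place of phenyl on a saturated chain carbon bound to an oxygen on a saturated carbon). Among the measured compounds shown here, no measured step covers exactly this change; the one step that resembles it, from compound 1 to compound 2, sits within the scatter, and the line the limit of > 100000 nM in this assay, at which 1 of the 2 values shown sits, shows one of the two values as a limit. A step of a 1.2-fold higher number from compound 2 to compound 3 (0.08 log units; within the scatter) is therefore expected, within the scatter. Compound 3 is estimated at 100000 nM, with a range from 40000 nM to 250000 nM.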

Compound 3, half-maximal cytotoxic concentration: 12000 nM
The estimate for compound 3 lay 8.3-fold (0.92 log units) above the measured number, outside the stated range (below it).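

In this assay, the ring at the end of the side chain turns out to matter, with a 7.0-fold lower number from compound 2 to compound 3 (0.85 log units; beyond the scatter) when furan-2-yl replaces phenyl on a saturated chain carbon bound to an oxygen on a saturated carbon. Since lower numbers stand for higher toxicity in this test, furan-2-yl is the more toxic choice here, and furan-2-yl in place of thiophen-3-yl gives an at least 8.3-fold lower number from compound 1 to compound 3 (0.92 log units; beyond the scatter). Compound 1 sits at > 100000 nM, which is a limit of the test and not a number, so this second step gives only a floor: the limit of > 100000 nM in this assay, at which 1 of the 3 values shown sits.

The compounds shown leave open whether the oxygen of the furan-2-yl ring or the ring as a whole goes with the lower number. They also leave open how furan-3-yl, a pyridine ring or an amine at this place would read in this assay.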